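Dropping one trifluoromethyl from the urea of compound 1

A few compounds are considered here, and "the series" means these few. Any claim that something is new, unique, unknown or untested is made for them only; others in the source may bear on it.

Compound 1 `O=C(Nc1cccc(-n2cc(-c3ccncc3)c(-c3ccc(Cl)c(O)c3)n2)c1)Nc1cc(C(F)(F)F)cc(C(F)(F)F)c1` gives 1580 nM in a functional assay on COLO 205 cells (Homo sapiens) for inhibition, read by sulforhodamine B assay, with a stated time of 48 h; on this read-out higher numbers stand for weaker inhibition of growth and lower numbers for stronger inhibition of growth. Among the three measured compounds it stands second highest: compound 2 `COc1cc(-c2nn(-c3cccc(NC(=O)Nc4ccc(Cl)c(C(F)(F)F)c4)c3)cc2-c2ccncc2)ccc1Cl` gives 1540 nM, within the scatter of compound 1, while compound 3 `COc1cc(-c2nn(-c3cccc(NC(=O)c4ccccc4)c3)cc2-c2ccncc2)ccc1Cl` gives 3230 nM. For the measured compounds named here, the only measured step, a 2.1-fold higher number from compound 2 to compound 3 (0.32 log units; beyond the scatter), changes the group on the carbonyl carbon and does not touch the ring altered here. Compound 4 `O=C(Nc1cccc(-n2cc(-c3ccncc3)c(-c3ccc(Cl)c(O)c3)n2)c1)Nc1cccc(C(F)(F)F)c1` differs from compound 1 by hydrogen in place of trifluoromethyl on an aromatic carbon. Going by the values given here, no measured step bears directly on this change; compound 1 and compound 2 carry different aryl groups on the urea yet give near-identical numbers, so only a small step, if any beyond the scatter, is expected, a 1.3-fold higher number from compound 1 to compound 4 (0.12 log units; within the scatter). Compound 4 is therefore estimated at 2100 nM, within 900 nM to 4800 nM.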

Compound 4, concentration for total growth inhibition: 23800 nM
Compound 4: middle estimate off by 11-fold (1.05 log units), on the low side; measured number outside the range, above it.
By their numbers in this assay, from the lowest: compounds 2 and 1 (each within the scatter of the next); then compound 3; then compound 4.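

In this assay, replacing this trifluoromethyl, on an aromatic carbon meta to a large group, with hydrogen gives a 15-fold higher number from compound 1 to compound 4 (1.18 log units; beyond the scatter). For the compounds shown here, this position on the urea's outer ring is therefore far more sensitive than the earlier compounds suggested, and hydrogen there costs much of the growth inhibition. Nothing measured here explains the step.

Going by these compounds, whether a methyl group or an amine at this place would stay near compound 1 or fall towards compound 4 remains open. So does whether the same change would cost as much on the core of compound 2.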